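This account rests on a few compounds, and the source may have more. Where it says the series, first, only, none or still open, it means among the compounds named here.

The series is followed in a functional assay on HepG2 cells (Homo sapiens) for inhibition, read by MTT assay, with a stated time of 72 h; on this read-out higher numbers stand for weaker inhibition and lower numbers for stronger inhibition. Compound 1 `Cc1ccc(-n2cc(CNC(=O)c3cccc4c3cnn4C(C)C)nn2)cc1C` carries a 3,4-dimethylphenyl on an aromatic nitrogen of the shared core; in this assay compound 1 gives no number but the limit > 40000 nM. Compound 2 `CC(C)n1ncc2c(C(=O)NCc3cn(-c4ccc([N+](=O)[O-])cc4)nn3)cccc21` carries a 4-nitrophenyl at that position; in this assay compound 2 likewise reaches only the limit > 40000 nM. Compound 3 `Cc1ccc(-n2cc(CNC(=O)c3cccc4c3cnn4C(C)C)nn2)cc1` carries a 4-methylphenyl there; in this assay compound 3 also stops at the limit > 40000 nM. The three steps a step that the two limits leave unreadable from compound 1 to compound 2, a step that the two limits leave unreadable from compound 1 to compound 3 and a step that the two limits leave unreadable from compound 2 to compound 3 therefore have no readable size. Compound 3 thus stands where the other two measured compounds stand, as summed up by the limit of > 40000 nM in this assay, at which 3 of the 3 values shown sit.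

Compound 4 `Cc1cccc(-n2cc(CNC(=O)c3cccc4c3cnn4C(C)C)nn2)c1` differs from compound 3 only by 3-methylphenyl in place of 4-methylphenyl on an aromatic nitrogen. Going by the values given here, no measured step gives a readable size for this change; the three steps among compounds 1, 2 and 3 are unreadable, and every value shown sits at the limit described by the limit of > 40000 nM in this assay, at which 3 of the 3 values shown sit. A reading within the scatter of compound 3 is therefore expected, so the step that the limit leaves unreadable from compound 3 to compound 4 is expected to show no direction beyond the scatter. Compound 4 is estimated at 60000 nM, between 20000 nM and 200000 nM, most likely reported once more only as a limit.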

Compound 4, half-maximal inhibitory concentration: > 40000 nM
Compound 4 was reported as a limit; the forecaster's own chance of this, stated with the estimate: 85%; the middle value does not contradict the limit.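

In this assay, going by these compounds alone, compound 4 gives > 40000 nM, a limit, so no step between it and compounds 1, 2 or 3 can be read. Left open is whether any of these aryl groups on the shared core differs from another in this assay, since the compounds shown yield only a limit: the limit of > 40000 nM in this assay, at which 4 of the 4 values shown sit.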